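This account rests on a few compounds, and the source may have more. Where it says the series, first, only, none or still open, it means among the compounds named here.

Measured compounds:
- compound 2, `CC(C)(C)c1ccc2oc(N3CCCN(C(=O)CC4CCCC4)CC3)nc2c1`, in a physicochemical assay for solubility, at pH 7.4 (a higher number here means a more soluble compound, a lower number a less soluble compound), gives 26 ug/mL
- compound 1, `CC(C)(C)c1cc(NC(=O)N2CCCN(c3ccc(C#N)cn3)CC2)no1`, in this assay gives 13 ug/mL

Compound 2 has the higher of the two numbers, but its nearest neighbour, compound 1, lies within the usual scatter of this kind of measurement, so the two cannot be ordered with any confidence. Compound 3, `CC(C)(C)c1ccc2oc(N3CCCN(C(=O)C4CCOCC4)CC3)nc2c1`, has not yet been measured in this assay. It differs from compound 2 in one place: oxan-4-yl in place of cyclopentylmethyl on a carbonyl carbon. The incoming group brings one hydrogen-bond acceptor where the outgoing group had none, and the rest of the structure is unchanged. For the measured compounds named here, no pair of measured compounds shows what such a change does in this assay, so the expectation rests on the structural change alone. The step from compound 2 to compound 3 is expected to be a 2.7-fold higher number from compound 2 to compound 3 (0.43 log units; beyond the scatter), an increase in solubility. Compound 3 is therefore estimated at 70 ug/mL, with a range from 30 ug/mL to 180 ug/mL.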

Compound 3, solubility: > 96 ug/mL
Compound 3: no number, only a limit (the forecaster's own chance of this, stated with the estimate: 5%); at least 1.3-fold (0.13 log units) between middle value and limit.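

In this assay, the result for compound 3 is a limit of the assay and not a number: the limit of > 96 ug/mL in this assay, at which 1 of the 3 values shown sits. Even so, the position on the carbonyl carbon now has a readable step, because replacing cyclopentylmethyl with oxan-4-yl gives an at least 3.6-fold higher number from compound 2 to compound 3 (0.56 log units; beyond the scatter), which compound 1 could not show since it differs from compound 2 in more than one place. Both groups carry 6 heavy atoms, so this step comes with no change in that count.

The compounds shown leave open whether the step belongs to the ring oxygen or to the change in ring and attachment, and a cyclohexyl group on the same carbonyl carbon would help separate these. Going by these compounds, how an amine such as piperidin-4-yl would behave there also remains open.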